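Amide heterocycle swap: aromatic ring to non-aromatic ring

The source may hold more compounds than are shown below. What is called first, only, known or untested is meant among the compounds shown, and "the series" means these compounds.

In a functional assay on CHO cells for agonist activity at Free fatty acid receptor 2 (Homo sapiens), read by cAMP accumulation (on this read-out higher numbers stand for larger maximal responses and lower numbers for smaller maximal responses), compound 3 `CC(C)[C@H](C(=O)Nc1ncns1)c1ccc(Cl)cc1` gives 99%, standing at the top of the two numbers shown, though a number 6 percentage points higher from compound 2 to compound 3 (within the scatter) lies within the scatter. Compound 2 `CC(C)[C@H](C(=O)Nc1ccc(F)cn1)c1ccc(Cl)cc1` in this assay gives 93%. Compound 1 `CC(C)[C@H](C(=O)Nc1ccccc1)c1ccc(Cl)cc1` in this assay reaches only a limit, < 30% (the limit of < 30% in this assay, at which 1 of the 3 values shown sits). The steps of a number at least 63 percentage points higher from compound 1 to compound 2 (beyond the scatter) and a number at least 69 percentage points higher from compound 1 to compound 3 (beyond the scatter) are both large, and both replace phenyl on the amide-type nitrogen with a heteroaromatic ring. Compound 4 `CC(C)[C@H](C(=O)NC1=NC(=O)CS1)c1ccc(Cl)cc1` carries a group of 6 heavy atoms (3 carbon, 1 nitrogen, 1 oxygen, 1 sulfur; one five-membered non-aromatic ring with 2 hetero atoms) in place of a group of 5 heavy atoms (2 carbon, 2 nitrogen, 1 sulfur; one five-membered aromatic ring with 3 hetero atoms), on an amide-type nitrogen. For the measured compounds named here, no measured step exchanges an aromatic five-membered ring for a non-aromatic one, so those two large steps bear on this change only indirectly. A moderate decrease in this assay is expected, a number 24 percentage points lower from compound 3 to compound 4 (beyond the scatter). Compound 4 is therefore estimated at 75%, with a range from 45% to 100%.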

Compound 4, largest response reached (reported as efficacy), in percent of the reference or control that the assay uses: 96%
For compound 4 the middle estimate is 21 percentage points below the measured one; low and high end bracket the measured number.
By their numbers in this assay, from the lowest: compounds 2, 4 and 3 (each within the scatter of the next). At a limit, below all of these: compound 1.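

In this assay, this position on the amide-type nitrogen tolerates a non-aromatic five-membered ring: a number 3 percentage points lower from compound 3 to compound 4 (within the scatter) and a number 3 percentage points higher from compound 2 to compound 4 (within the scatter), so compound 4 is not separated from either heteroaromatic compound. The large gain over phenyl also holds for this non-aromatic ring, with a number at least 66 percentage points higher from compound 1 to compound 4 (beyond the scatter). Compound 1 stands at a limit, not at a number: the limit of < 30% in this assay, at which 1 of the 4 values shown sits.

The compounds shown leave open whether aromatic and non-aromatic rings remain equivalent beyond this one pair. They also leave open whether a fully saturated ring such as pyrrolidine, or a plain methyl group, would serve on this nitrogen.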